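Fluorophenyl position in a trifluoromethyl oxazole amide series

The compounds below may be only part of what the source reports. "The series", "measured", "known", "first", "only" and "open" are said of these compounds alone.

Compounds with values in hand:
Compound 1, `CCc1nc(-c2cccc(F)c2)c(C(=O)N2CCN(c3cccc(OC)c3)CC2)o1`, 201 nM
Compound 2, `COc1cccc(N2CCN(C(=O)c3oc(C(F)(F)F)nc3-c3cccc(F)c3)CC2)c1`, "not active" (no number reported)
Compound 3, `COc1cccc(N2CCN(C(=O)c3oc(C)nc3-c3cccc(F)c3)CC2)c1`, "not active" (no number reported)

The account turns on compound 2. In a functional assay on HL-60 cells (Homo sapiens) for inhibition, read by MTT assay, with a stated time of 72 h (a lower number here means a stronger inhibitor, a higher number a weaker inhibitor), compound 2 gives "not active" (no number reported), so no single number stands for it; compound 3 likewise stands without a single number, "not active" (no number reported), and only compound 1 gives a number, 201 nM. Compound 2 therefore sits at the weak end of what is shown, with no scale by which to place it against compound 1 beyond that.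

Compound 4, `COc1cccc(N2CCN(C(=O)c3oc(C(F)(F)F)nc3-c3ccc(F)cc3)CC2)c1`, has the same atoms as compound 2 joined differently: 4-fluorophenyl in place of 3-fluorophenyl on an aromatic carbon. Within the data shown here, no measured pair tells what such a change does here, so in this assay a step of no clear direction is expected, and none that would carry compound 4 far from where compound 2 stands; the reading for compound 4 is expected to stay near the weak end, with a fair chance of no number at all. Compound 4 is estimated at 20000 nM, in the range 3000 nM to 100000 nM.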

Compound 4, half-maximal inhibitory concentration: "not active" (no number reported)
For compound 4 the study gives words and no number, and the estimate cannot be compared.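

In this assay compound 2 and compound 4 both stand without a number, so no step can be read between them. No evidence shown bears on this result. The compounds shown leave open what 4-fluorophenyl in place of 3-fluorophenyl does to potency.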